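From fluoro to chloro on the benzimidazole

The source may hold more compounds than are shown below. What is called first, only, known or untested is meant among the compounds shown, and "the series" means these compounds.

Measured so far in a functional assay on Hep 3B2 cells (Homo sapiens) for cytotoxicity, read by MTT assay; a higher number here means a weaker inhibitor, a lower number a stronger inhibitor:
- Compound 1 `CC(=O)N1CCC(C[C@@H](c2nc3ccc(C)cc3n2C)N2C(=O)CN(c3ccc(Oc4ccccc4)cc3)C2=O)CC1` gives 17200 nM as a number
- Compound 2 `CC(=O)N1CCC(C[C@@H](c2nc3cc(F)ccc3n2C)N2C(=O)CN(c3ccc(Oc4ccccc4)cc3)C2=O)CC1` gives > 100000 nM as a limit

Compound 2 stands at the weak end of this small set. Its reading of > 100000 nM is a limit of the assay and not a number.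

Compound 3 `CC(=O)N1CCC(C[C@@H](c2nc3ccc(Cl)cc3n2C)N2C(=O)CN(c3ccc(Oc4ccccc4)cc3)C2=O)CC1` carries 6-chloro-1-methyl-1H-benzimidazol-2-yl in place of 5-fluoro-1-methyl-1H-benzimidazol-2-yl, on a saturated chain carbon bound to an amide-type nitrogen in a ring and a saturated chain carbon (6-chloro-1-methyl-1H-benzimidazol-2-yl in place of 5-fluoro-1-methyl-1H-benzimidazol-2-yl on a saturated chain carbon bound to an amide-type nitrogen in a ring and a saturated chain carbon). The rest of the molecule stays the same.

Among the compounds with values here, only one measured step changes this same group: an at least 5.8-fold higher number from compound 1 to compound 2 (0.76 log units; beyond the scatter). It lies beyond the scatter, so a change here can shift the reading in this assay noticeably. The name of the new group carries its substituent at 6, as the group of compound 1 (17200 nM) does, so a move towards that compound is expected. The expected step is an at least 3.3-fold lower number from compound 2 to compound 3 (0.52 log units; beyond the scatter), though the limit leaves its size uncertain. For compound 3 the estimated value is 30000 nM (expected range 10000 nM to 100000 nM).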

Compound 3, half-maximal inhibitory concentration: > 100000 nM
Compound 3: a limit, no number; the forecaster's own chance of this, stated with the estimate: 30%; at least 3.3-fold (0.52 log units) between middle value and limit.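

In this assay, compound 3 joins compound 2 in giving a reading that is a limit of the assay and not a number. Chloro in place of methyl on an aromatic carbon gives an at least 5.8-fold higher number from compound 1 to compound 3 (0.76 log units; beyond the scatter), a change of a single substituent that leaves the rest of the molecule as it is. This shows that having a substituent at 6 does not by itself give a measurable reading here: among these compounds, the methyl of compound 1 gives a number and the chloro of compound 3 does not. Fluoro and chloro cannot be ranked against each other, and the step between compound 2 and compound 3 cannot be read, because both readings stop at the same edge of the assay: the limit of > 100000 nM in this assay, at which 2 of the 3 values shown sit.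

Within the data shown here, with compound 1 the only one that gives a number, these compounds cannot tell whether methyl is unusual on that aromatic carbon or whether other groups would also give a number there. Going by these compounds, a methoxy group, an ethyl group or an amine in its place would test this, and the answer remains open.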